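Methoxy for fluoro on a shared thienopyridine-free core

A few compounds are considered here, and "the series" means these few. Any claim that something is new, unique, unknown or untested is made for them only; others in the source may bear on it.

This account follows four close relatives built on one shared core. Compound 1 `N#Cc1c(NCc2ccccc2)sc2c1CCN(C(=O)c1ccc(F)cc1)C2` carries a benzyl amine and a fluorophenyl carbonyl; in a functional assay on cells (kidney) for antagonist activity at metabotropic glutamate receptor 5 (Homo sapiens), read by fluorescence and calcium flux (on this read-out lower numbers stand for stronger inhibition and higher numbers for weaker inhibition), compound 1 gives "not determined" (no result reported). Compound 2 `COc1ccc(C(=O)N2CCc3c(sc(NCc4ccc(F)cc4)c3C#N)C2)cc1` pairs a 4-fluorobenzyl amine with a methoxyphenyl carbonyl, and in this assay compound 2 gives 1430 nM. Compound 3 `N#Cc1c(NCc2cccc(F)c2)sc2c1CCN(C(=O)c1ccc(F)cc1)C2` keeps the fluorophenyl carbonyl of compound 1 but bears a 3-fluorobenzyl amine; in this assay compound 3 gives "not determined" (no result reported), so no number stands for it, and one further relative is likewise without a number. On the numbers shown, compound 3 therefore cannot be placed against compound 2.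

Compound 4 `COc1ccc(C(=O)N2CCc3c(sc(NCc4cccc(F)c4)c3C#N)C2)cc1` differs from compound 3 in one place: methoxy in place of fluoro on an aromatic carbon. The change is methoxy in place of fluoro on an aromatic carbon, para to a large group. Going by the values given here, no measured pair shows this step, so its size and direction are open. Among the compounds with values here, the only number in hand is that of compound 2, a near relative of compound 4 that also carries the methoxyphenyl carbonyl. Compound 4 is estimated to sit near that level in this assay, about 1500 nM, expected between 500 nM and 5000 nM.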

Compound 4, half-maximal inhibitory concentration: 4730 nM
Beside the measured number, compound 4's estimate is 3.2-fold (0.50 log units) below it; the measured number falls inside the stated range.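

Going by these compounds alone, with compound 4 measured, the shared core yields its one readable step in this assay: 3-fluorophenyl in place of 4-fluorophenyl, on the saturated chain carbon bound to a nitrogen on an aromatic ring, gives a 3.3-fold higher number from compound 2 to compound 4 (0.52 log units; beyond the scatter), and this lies beyond the scatter. The earlier compounds shown here could not show that the place of the fluorine on this benzyl group matters; with the (4-methoxyphenyl)carbonyl held the same in this pair, the 4-fluorophenyl form, compound 2, carries the lower number and so the stronger inhibition. Nothing measured here bears on what lies behind this difference.

As far as these compounds go, the steps from compound 3 to compound 4 and from compound 1 to any relative cannot be read, as neither compound 3 nor compound 1 has a number, so the size and direction of the change from 4-fluorophenyl to 4-methoxyphenyl on the carbonyl stay open. Also open, from the compounds shown here alone, is how a chloro or a hydroxy on either aromatic ring, or a longer chain in place of the benzyl group, would read in this assay.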